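The compounds below may be only part of what the source reports. "The series", "measured", "known", "first", "only" and "open" are said of these compounds alone.

Working notes on the cinnamamide series. Compound 1 `CN(C)CCC(NC(=O)/C=C/c1ccccc1)c1ccc2ccccc2c1` is taken as the reference; compound 3 `CN(C)CCC(NC(=O)/C=C/c1ccccc1)c1ccc(Cl)cc1` and compound 2 `COc1ccc(/C=C/C(=O)NC(CCN(C)C)c2ccc(Cl)cc2)cc1` share a different core. The difference between the core of compound 1 and the core of compound 3 is not broken down here.

In a functional assay on NIH3T3 cells for agonist activity at Urotensin-2 receptor (Homo sapiens), with a stated time of 5 days (a higher number here means that more compound is needed for the effect, a lower number that less compound is needed), compound 1 gives 589 nM. Compound 3 gives 427 nM and compound 2 gives 513 nM in this assay; all three numbers lie within the scatter of one another, so no order among them is claimed.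

One change is seen once and is now repeated. From compound 3 to compound 2 the change is methoxy in place of hydrogen on an aromatic carbon, and it gave a 1.2-fold higher number from compound 3 to compound 2 (0.08 log units; within the scatter). Compound 4 `COc1ccc(/C=C/C(=O)NC(CCN(C)C)c2ccc3ccccc3c2)cc1` carries the same change made on compound 1, namely (methoxy in place of hydrogen on an aromatic carbon); the place is the same in both cases.

Resting on the single measured step of a 1.2-fold higher number from compound 3 to compound 2 (0.08 log units; within the scatter), the step is expected to be a 1.2-fold higher number from compound 1 to compound 4 (0.07 log units; within the scatter), since nothing in the data suggests the methoxy behaves differently on the core of compound 1. Compound 4 is thus estimated at 700 nM, with a likely range from 350 nM to 1400 nM.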

Compound 4, half-maximal effective concentration: 380 nM
Estimate against measurement, compound 4: 1.8-fold (0.27 log units) above; the measured number falls inside the stated range.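

In this assay, methoxy in place of hydrogen on an aromatic carbon can now be read on a second core, where the new step is a 1.6-fold lower number from compound 1 to compound 4 (0.19 log units; within the scatter). Set beside the earlier step, the two readings do not separate: the same change on two cores in this assay, a 1.2-fold higher number (0.08 log units; within the scatter) from compound 3 to compound 2 and a 1.6-fold lower number (0.19 log units; within the scatter) from compound 1 to compound 4, 1.9-fold (0.27 log units) apart, within the scatter of two such steps. This fits the change carrying over between the core of compound 3 and the core of compound 1, but with both steps inside the scatter it shows only that the methoxy gave no readable difference on either core, not that it has a real effect of either sign or that its effect depends on the core.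

The compounds shown leave open whether a group other than methoxy at the same place, such as a hydroxyl or a trifluoromethyl, would give a step beyond the scatter on either core. Also open, going by these compounds, is what happens when the dimethylamino end is replaced by a primary amine or a carboxylic acid.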